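Acetyl in place of hydrogen on a dichlorophenol amide

The compounds below may be only part of what the source reports. "The series", "measured", "known", "first", "only" and "open" are said of these compounds alone.

In an ADME assay on HEK-293T cells (Homo sapiens) for cytotoxicity, read by MTT assay, tested at 100 uM (on this read-out lower numbers stand for a stronger effect and higher numbers for a weaker effect at the one concentration tested), compound 2 `O=C(Nc1ncc([N+](=O)[O-])s1)c1cc(Cl)cc(Cl)c1O` gives 23.5%. Of the two numbers in hand, the other belongs to compound 1 `CC(=O)Oc1ccc(Cl)cc1C(=O)Nc1ncc([N+](=O)[O-])s1`, which in this assay gives 31.2%; the two values lie within the usual scatter of each other. Compound 3 `CC(=O)Oc1c(Cl)cc(Cl)cc1C(=O)Nc1ncc([N+](=O)[O-])s1` has not yet been measured. It differs from compound 2 by acetyl in place of hydrogen on an oxygen on an aromatic ring. Among the measured compounds shown here, no step between measured compounds is available, so the expected step of a number 3.5 percentage points higher from compound 2 to compound 3 (within the scatter) is small, in no clear direction, and not beyond the scatter. Compound 3 is estimated at 27%, with a range from 15% to 42%.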

Compound 3, a percentage reported as activity, at one concentration (the size of the read-out at that concentration, not a potency): 95.1%
Compound 3: middle estimate off by 68.1 percentage points, on the low side, outside the stated range (above it).
By their numbers in this assay, from the lowest: compounds 2 and 1 (each within the scatter of the next); then compound 3.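

Replacing hydrogen with acetyl on the oxygen on an aromatic ring is a large change in this assay (a number 71.6 percentage points higher from compound 2 to compound 3 (beyond the scatter)) here, which the two earlier compounds could not show. Chloro in place of hydrogen on an aromatic carbon is also large (a number 63.9 percentage points higher from compound 1 to compound 3 (beyond the scatter)), so compound 3 stands apart from both of its single-change neighbours. Nothing measured here accounts for either step.

On these data alone, it remains open whether a methyl ether or a longer acyl chain on that oxygen would give a similar read-out. A single compound also cannot show whether the step depends on having both the acetyl and the added chloro.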